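Adding one chain carbon to compound 3

The compounds below may be only part of what the source reports. "The series", "measured", "known", "first", "only" and "open" are said of these compounds alone.

Compound 1 `CC(C)CCc1c(OCCCCCCCC(=O)NO)ccc(CCC(=O)NO)c1O` gives 2670 nM
Compound 2 `CC(C)CCc1c(OCCCCCCC(=O)NO)ccc2ccc(=O)oc12` gives 660 nM
Compound 3 `CC(C)CCc1c(OCCCCC(=O)NO)ccc(CCC(=O)NO)c1O` gives 10000 nM

In a functional assay on A549 cells (Homo sapiens) for antiproliferative activity, read by sulforhodamine B assay, with a stated time of 48 h (a lower number here means a stronger inhibitor of growth, a higher number a weaker inhibitor of growth), compound 3 has the highest number of the three, making it the weakest measured inhibitor. Compound 4 `CC(C)CCc1c(OCCCCCC(=O)NO)ccc(CCC(=O)NO)c1O` differs from it by one change: (hydroxycarbamoyl)methyl in place of hydroxycarbamoyl ((hydroxycarbamoyl)methyl in place of hydroxycarbamoyl on a saturated chain carbon, four bonds along the chain from an oxygen on an aromatic ring). Among the measured compounds shown here, one measured step bears on this change, on the same chain: a 3.7-fold higher number from compound 1 to compound 3 (0.57 log units; beyond the scatter), as 3-(hydroxycarbamoyl)propyl gave way to hydroxycarbamoyl. The chain of compound 4 falls between those two, so only part of that step should appear. Compound 2 differs in more than one place and offers no direct guide. A small move toward a lower number is expected, probably within the scatter: a 1.7-fold lower number from compound 3 to compound 4 (0.22 log units; within the scatter) (estimated). The estimate for compound 4 is 6000 nM (expected range 2700 nM to 11000 nM).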

Compound 4, concentration for 50% growth inhibition: 5410 nM
Estimate against measurement, compound 4: 1.1-fold (0.04 log units) above, and the stated range covers the measured number.
By their numbers in this assay, from the lowest: compound 2; then compound 1; then compounds 4 and 3 (each within the scatter of the next).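

In this assay this one-carbon extension gives a 1.8-fold lower number from compound 3 to compound 4 (0.27 log units; within the scatter) and so makes no readable difference at this place on the chain. The longer chain does give a 2.0-fold higher number from compound 1 to compound 4 (0.31 log units; beyond the scatter) in the reverse direction, so in these three chain lengths a difference beyond the scatter appears only with the chain of compound 1. Nothing measured here explains this dependence on chain length. Still open, as far as these compounds go, is whether a longer chain than that of compound 1 would lower the number further, and how a carboxylic acid would compare with the hydroxycarbamoyl end.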